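Swapping a Piperidine for Diethylamine on Isatin Amides

This account rests on a few compounds, and the source may have more. Where it says the series, first, only, none or still open, it means among the compounds named here.

Measured so far, in a functional assay on MDA-MB-468 cells (Homo sapiens) for cytotoxicity, read by sulforhodamine B assay, with a stated time of 48 h; on this read-out lower numbers stand for stronger inhibition of growth and higher numbers for weaker inhibition of growth:
compound 1 `CCN(CC)CN1C(=O)/C(=N\c2nc3ccc(C)cc3s2)c2ccccc21` gives 63500 nM;
compound 2 `Cc1ccc2nc(/N=C3\C(=O)N(CN4CCCCC4)c4ccccc43)sc2c1` gives 65600 nM;
compound 3 `O=C1C(=O)N(CN2CCCCC2)c2cccc(Br)c21` gives 35300 nM.

Compound 2 and compound 1 share one core and differ only in one group: diethylamino in place of piperidin-1-yl on a saturated chain carbon bound to an amide-type nitrogen in a ring. The step that went with this change, a 1.0-fold lower number from compound 2 to compound 1 (0.01 log units; within the scatter), is small enough to count as no change at all. Compound 3 is built on a different core, and the difference between the two cores is not broken down here. Its number stands apart from those of compound 1 and compound 2 only by amounts that fall within the usual scatter, so nothing can be said about which of the three is stronger.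

Compound 4 `CCN(CC)CN1C(=O)C(=O)c2c(Br)cccc21` has not yet been measured in this assay. It is made from compound 3 by exactly the same change: diethylamino in place of piperidin-1-yl on a saturated chain carbon bound to an amide-type nitrogen in a ring. The place where the new group sits is described in the same words in both pairs, so this is the same change, applied to a different core.

Because the earlier step, a 1.0-fold lower number from compound 2 to compound 1 (0.01 log units; within the scatter), was too small to register, the expectation for compound 4 in this assay is that it will stay close to compound 3, with an estimated step of a 1.0-fold lower number from compound 3 to compound 4 (0.00 log units; within the scatter). Compound 4 is therefore estimated to give about 35000 nM, with a range from 15000 nM to 80000 nM expected to hold most repeated measurements.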

Compound 4, concentration for 50% growth inhibition: 11700 nM
Estimate against measurement, compound 4: 3.0-fold (0.48 log units) above; the whole stated range lies above it.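

Diethylamino in place of piperidin-1-yl did not behave the same way on both cores. On the core of compound 3, in this assay, the change went with a 3.0-fold lower number from compound 3 to compound 4 (0.48 log units; beyond the scatter), so growth inhibition became modestly stronger, whereas the same swap on the core of compound 1 made no visible difference. The gap between the two steps is larger than chance scatter would readily explain, which shows that the size of this step cannot simply be carried from one core to the other in these pairs: the same change on two cores in this assay, a 1.0-fold lower number (0.01 log units; within the scatter) from compound 2 to compound 1 and a 3.0-fold lower number (0.48 log units; beyond the scatter) from compound 3 to compound 4, 2.9-fold (0.47 log units) apart, beyond the scatter of two such steps. This does not show why the cores differ, since they differ in more than one place and two pairs cannot single out the part that matters, nor does it show how the change would behave on any third core.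

From the compounds shown here alone, it remains open whether other amines on the same chain carbon, such as dimethylamino, pyrrolidin-1-yl or morpholin-4-yl, would follow compound 4 or compound 3 on this core. Going by these compounds, it is also open whether the step depends on the bromine of compound 3, a question that a matched pair with chlorine or hydrogen in its place could address.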